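Swapping the aryl group on the ring nitrogen of compound 1

This account rests on a few compounds, and the source may have more. Where it says the series, first, only, none or still open, it means among the compounds named here.

Compound 1 `COc1ncc(-c2ccc3c(c2)N(c2ccc(C)cc2)C(=O)CO3)cc1NS(=O)(=O)c1ccc(F)cc1` was tested in a functional assay on HCT-116 cells (Homo sapiens) for antiproliferative activity, read by MTT assay, with a stated time of 72 h (on this read-out higher numbers stand for weaker inhibition and lower numbers for stronger inhibition), where compound 1 gives 22700 nM. Compound 2 `Cc1ccc(N2C(=O)COc3ccc(-c4cnc(Cl)c(NS(=O)(=O)c5ccc(F)cc5)c4)cc32)cc1` gives 34300 nM and compound 3 `O=C1COc2ccc(-c3cccc(NS(=O)(=O)c4ccc(F)cc4)c3)cc2N1c1ccc(Cl)cc1` gives 23900 nM, so compound 1 stands within the scatter of both. The step of a 1.5-fold higher number from compound 1 to compound 2 (0.18 log units; within the scatter) came with chloro in place of methoxy on an aromatic carbon, a different place from the one now altered. Compound 4 `COc1cccc(N2C(=O)COc3ccc(-c4cnc(OC)c(NS(=O)(=O)c5ccc(F)cc5)c4)cc32)c1` differs from compound 1 thus: 3-methoxyphenyl in place of 4-methylphenyl on an amide-type nitrogen in a ring. Among the measured compounds shown here, no measured step changes this ring nitrogen alone; compound 3 carries another group on it but also differs elsewhere, and its value and that of compound 1 lie within the scatter. Compound 4 is therefore expected to show a 1.1-fold higher number from compound 1 to compound 4 (0.04 log units; within the scatter), nothing beyond the scatter, with an estimated value of 25000 nM and a range from 10000 nM to 60000 nM.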

Compound 4, half-maximal inhibitory concentration: > 40000 nM
Compound 4: only a limit was reported (the forecaster's own chance of this, stated with the estimate: 10%); middle value at least 1.6-fold (0.20 log units) from the limit.
By their numbers in this assay, from the lowest: compounds 1, 3 and 2 (each within the scatter of the next). At a limit, above all of these: compound 4.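

Among the compounds shown here, on the amide-type nitrogen in the ring, 3-methoxyphenyl in place of 4-methylphenyl gave an at least 1.7-fold higher number from compound 1 to compound 4 (0.24 log units; that floor lies within the scatter), the first step that alters this place alone. Compound 4 has a limit rather than a number in this assay: the limit of > 40000 nM in this assay, at which 1 of the 4 values shown sits. Going by these compounds, the floor of this step lies within the scatter, so the swap brought no lower number, and its true size remains unknown.

The compounds shown leave open whether an amine or a carboxylic acid on this phenyl ring would give a lower number. They also do not separate the gain of the methoxy group from the loss of the methyl group.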